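Tert-butyl for cyclohexyl on the amide nitrogen

A few compounds are considered here, and "the series" means these few. Any claim that something is new, unique, unknown or untested is made for them only; others in the source may bear on it.

In a functional assay on CAL-27 cells (Homo sapiens) for cytotoxicity, read by MTT assay, with a stated time of 72 h (on this read-out lower numbers stand for stronger inhibition and higher numbers for weaker inhibition), compound 1 `O=C(CCCCCN(CC(=O)NC1CCCCC1)C(=O)c1ccccc1)NO` gives 3800 nM, at the upper end of the numbers together with compound 2 `CN(C)c1ccc(C(=O)N(CCCCCC(=O)NO)CC(=O)NC2CCCCC2)cc1` at 2970 nM, while compound 3 `Cc1cc(C)cc(C(=O)N(CCCCCC(=O)NO)CC(=O)NC2CCCCC2)c1` gives 1130 nM. Compound 4 `CC(C)(C)NC(=O)CN(CCCCCC(=O)NO)C(=O)c1ccccc1` differs from compound 1 as follows: tert-butyl in place of cyclohexyl on an amide-type nitrogen. The measured steps all alter the phenyl group on the carbonyl carbon: a 1.3-fold lower number from compound 1 to compound 2 (0.11 log units; within the scatter) and a 3.4-fold lower number from compound 1 to compound 3 (0.53 log units; beyond the scatter). For the measured compounds named here, they bear on this change only indirectly, and no measured compound varies the cyclohexyl group. No step beyond the scatter is therefore expected in this assay, and the estimated step is a 1.1-fold higher number from compound 1 to compound 4 (0.02 log units; within the scatter). Compound 4 is expected at 4000 nM, with an estimated range of 1800 nM to 9000 nM.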

Compound 4, half-maximal inhibitory concentration: 16700 nM
For compound 4 the middle estimate is 4.2-fold (0.62 log units) below the measured one; measured number above the stated range.
By their numbers in this assay, from the lowest: compound 3; then compounds 2 and 1 (each within the scatter of the next); then compound 4.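

In this assay, the amide-type nitrogen proves to be a position that responds to change: with tert-butyl in place of cyclohexyl there is a 4.4-fold higher number from compound 1 to compound 4 (0.64 log units; beyond the scatter), a step beyond the scatter. For the compounds shown here, this is the first step outside the phenyl group on the carbonyl carbon, and it goes towards higher numbers, unlike the step to the 3,5-dimethylphenyl compound. No evidence here accounts for this step.

As far as these compounds go, whether the ring itself matters remains open, as a cyclopentyl or an open n-hexyl group on this nitrogen would show. Also open, from the compounds shown here alone, is whether 3,5-dimethylphenyl lowers the number when tert-butyl is present.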